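Swapping the side chain on a shared core

The compounds below may be only part of what the source reports. "The series", "measured", "known", "first", "only" and "open" are said of these compounds alone.

Measured in an ADME assay on microsomes from liver (Homo sapiens) for metabolic stability, read by LC-MS, tested at 1 uM; a higher number here means faster removal of the compound, a lower number slower removal:
- compound 1 `NC1CCN(S(=O)(=O)c2ccc([C@H]3CC[C@]4(CC3)OOC3(O4)C4CC5CC(C4)CC3C5)cc2)CC1`: < 7 mL.min-1.g-1 (a limit)
- compound 2 `N[C@H]1CC[C@@H](Oc2ccc([C@H]3CC[C@]4(CC3)OOC3(O4)C4CC5CC(C4)CC3C5)cc2)CC1`: < 7 mL.min-1.g-1 (a limit)

Compound 2 gives only a limit, < 7 mL.min-1.g-1, not an exact number. The evidence so far is the limit of < 7 mL.min-1.g-1 in this assay, at which 2 of the 2 values shown sit. For the measured compounds named here, the one measured step is a step that the two limits leave unreadable from compound 1 to compound 2, so it offers no size to carry forward.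

Compound 3 `CC(C)(CN)Oc1ccc([C@H]2CC[C@]3(CC2)OOC2(O3)C3CC4CC(C3)CC2C4)cc1` differs from compound 2 in one group: 1-(aminomethyl)-1-methylethyl in place of 4-aminocyclohexyl on an oxygen on an aromatic ring. With no readable step as a guide, no clear change in this assay is expected. The expected step is a step that the limit leaves unreadable from compound 2 to compound 3. For compound 3 the estimate is 6 mL.min-1.g-1, with an expected range from 3 mL.min-1.g-1 to 14 mL.min-1.g-1.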

Compound 3, intrinsic clearance in microsomes in the liver assay: < 7 mL.min-1.g-1
Compound 3: no number, only a limit (the forecaster's own chance of this, stated with the estimate: 60%); the middle value is on the limit's open side.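

In the liver assay compound 3 gives < 7 mL.min-1.g-1, which is a limit and not a number. For the compounds shown here, compound 1 and compound 2 also give only limits there, so no step among the three can be read: the limit of < 7 mL.min-1.g-1 in the liver assay, at which 3 of the 3 values shown sit. Going by these compounds, how quickly each of the three is actually removed, and whether they differ at all, stays open.

In a physicochemical assay for solubility, read by nephelometry, measured as kinetic solubility, with a stated time of 30 min (a higher number here means a more soluble compound, a lower number a less soluble compound), compound 2 gives 25 ug/mL. In the physicochemical assay compound 3 gives > 100 ug/mL, which is a limit and not a number. In the physicochemical assay the step is an at least 4.0-fold higher number from compound 2 to compound 3 (0.60 log units; beyond the scatter).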